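The source may report more compounds than this note shows. Statements on the series, on what has been measured and on what is new or still open speak of the compounds shown alone.

Of the compounds shown here, three of this set have so far been tested in a functional assay on HCT-116 cells (Homo sapiens) for cytotoxicity, read by MTT assay, with a stated time of 48 h; on this read-out higher numbers stand for weaker inhibition and lower numbers for stronger inhibition. Compound 1 `O=[N+]([O-])c1ccc2[nH]c(CSCc3nc4ccccc4[nH]3)nc2c1` gives 7910 nM, and compound 3 `CCOC(=O)c1c(NC(=O)CSCc2nc3cc([N+](=O)[O-])ccc3[nH]2)sc2c1CCCCC2` gives 7510 nM; these two values sit within the scatter of each other. Compound 2 `CCOC(=O)CSCc1nc2cc([N+](=O)[O-])ccc2[nH]1` returns only a limit of the assay, > 100000 nM, which places it at the weak end of what has been measured, the limit being (the limit of > 100000 nM in this assay, at which 1 of the 3 values shown sits). Among the measured compounds shown here, no two measured compounds differ from one another in a single place, so no measured step offers a scale for the change now in hand. Compound 4 `NC(=S)NNC(=O)CSCc1nc2cc([N+](=O)[O-])ccc2[nH]1` differs from compound 2 by a group of 5 heavy atoms (1 carbon, 3 nitrogen, 1 sulfur; no ring) in place of a group of 3 heavy atoms (2 carbon, 1 oxygen; no ring), on a carbonyl carbon. The expected direction is toward stronger inhibition, with the step of an at least 5.0-fold lower number from compound 2 to compound 4 (0.69 log units; beyond the scatter) bounded from one side only, since compound 2 stands at a limit rather than a number. Compound 4 is estimated at 20000 nM, with a range running from 5000 nM to 100000 nM, and with a fair chance that it too returns only a limit.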

Compound 4, half-maximal inhibitory concentration: 4710 nM
Beside the measured number, compound 4's estimate is 4.2-fold (0.63 log units) above it; the measured number lies below the stated range.
By their numbers in this assay, from the lowest: compounds 4, 3 and 1 (each within the scatter of the next). At a limit, above all of these: compound 2.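

In this assay, putting the group of 5 heavy atoms (1 carbon, 3 nitrogen, 1 sulfur) in place of ethoxy, on a carbonyl carbon whose other neighbour is a saturated chain carbon, gives an at least 21-fold lower number from compound 2 to compound 4 (1.32 log units; beyond the scatter). Among the compounds shown here, this is the first step in the set that rests on a change in one place, and it shows that the read-out at this position responds strongly to what is attached to that carbonyl carbon. Its full size cannot be given, since the value for compound 2 is only a limit: the limit of > 100000 nM in this assay, at which 1 of the 4 values shown sits.

The compounds shown do not separate the contributions of the sulfur and the nitrogens within the entering group. As far as these compounds go, how a carboxylic acid, a primary amide or a simple hydrazide on the same carbonyl carbon would read in this assay remains open.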